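The source may report more compounds than this note shows. Statements on the series, on what has been measured and on what is new or still open speak of the compounds shown alone.

Measured compounds in a functional assay on MCF7 cells (Homo sapiens) for antiproliferative activity, read by MTT assay, with a stated time of 24 h; on this read-out higher numbers stand for weaker inhibition and lower numbers for stronger inhibition:

- compound 1, `COc1ccc(-c2noc(-c3ccc(F)cc3)n2)cc1O`: gives > 1000000 nM, a limit of the assay rather than a number.
- compound 2, `COc1ccc(-c2noc(-c3cccnc3)n2)cc1OC1CCCC1`: gives > 1000000 nM, also a limit of the assay.
- compound 3, `COc1ccc(-c2noc(Cc3c[nH]c4ccccc34)n2)cc1OC1CCCC1`: gives > 1000000 nM, again a limit of the assay.

Compound 2 therefore stands at the limit of this assay; no number for it is known, and the same holds for the other two values shown: the limit of > 1000000 nM in this assay, at which 3 of the 3 values shown sit. For the measured compounds named here, no measured step between two compounds is available, so nothing can be said about how any one change has shifted the read-out.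

Compound 4, `COc1ccc(-c2noc(C3CCNCC3)n2)cc1OC1CCCC1`, is not yet measured. It differs from compound 2 in one place: piperidin-4-yl in place of pyridin-3-yl on an aromatic carbon. Given that compound 2 sits at the limit, with the value > 1000000 nM, the expected step in this assay from compound 2 to compound 4 is a number no higher from compound 2 to compound 4 (the limit leaves the size open), that is, none beyond the usual scatter. Compound 4 is accordingly expected to give about 1000000 nM, within the range 300000 nM to 3000000 nM, most likely reported again only as a limit.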

Compound 4, half-maximal inhibitory concentration: 3880 nM
For compound 4 the middle estimate is 260-fold (2.41 log units) above the measured one, and the stated range ends above it.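

In this assay, for the compounds shown here, the aromatic carbon of the five-membered ring, next to the ring nitrogen and the ring oxygen, proves sensitive to its substituent, which the earlier compounds could not show: piperidin-4-yl in place of pyridin-3-yl gives an at least 250-fold lower number from compound 2 to compound 4 (2.41 log units; beyond the scatter). The two groups have the same heavy-atom count and the same carbon and nitrogen make-up, so the change lies in a non-aromatic ring replacing an aromatic one and in the added hydrogen-bond donor, and these two differences cannot be separated here. Compound 4 is the only compound here with a value off the limit, so the step is open-ended on the side of compound 2: the limit of > 1000000 nM in this assay, at which 3 of the 4 values shown sit.

A cyclohexyl ring would test whether the ring nitrogen is needed at all, and a 1-methylpiperidin-4-yl group whether its hydrogen is. An open-chain amine would show whether the ring itself matters.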